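Working notes: one stereocentre changed in compound 2

The source may hold more compounds than are shown below. What is called first, only, known or untested is meant among the compounds shown, and "the series" means these compounds.

- compound 1 `CO[C@H](c1ccccc1)[C@H]1O[C@@H]2CC(=O)O[C@@H]2[C@H]1O`: 5640 nM
- compound 2 `CO[C@@H]1[C@H]2OC(=O)C[C@H]2O[C@@H]1[C@@H](OC)c1ccccc1`: 89300 nM

In a functional assay on HeLa cells (Homo sapiens) for inhibition, read by MTT assay, with a stated time of 72 h (on this read-out higher numbers stand for weaker inhibition and lower numbers for stronger inhibition), compound 2 stands highest of the two measured compounds at 89300 nM and compound 1, at 5640 nM on the same read-out, lies beyond the scatter from it.

Compound 3 `CO[C@@H]1[C@H]2OC(=O)C[C@H]2O[C@@H]1[C@H](OC)c1ccccc1` is unmeasured. Against compound 2 it shows the two compounds have the same atoms and bonds and differ only in configuration as drawn: 1 of 5 stereo elements differ; a stereocentre at a saturated chain carbon is drawn S in compound 2 and R in compound 3 in the structure: the two have the same atoms and bonds, and a stereocentre at a saturated chain carbon is drawn S in compound 2 and R in compound 3.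

Going by the values given here, no measured pair isolates a change of configuration, so the expectation is weakly grounded. A modest move to a lower number is expected, given that compound 2 holds the higher value of 89300 nM in this series. The estimated move is a 2.6-fold lower number from compound 2 to compound 3 (0.41 log units; beyond the scatter) in this assay on this reasoning. For compound 3 the estimated value is 35000 nM within an expected range from 8000 nM to 120000 nM on this read-out.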

Compound 3, half-maximal inhibitory concentration: 56400 nM
Compound 3: middle estimate off by 1.6-fold (0.21 log units), on the low side; the measured number falls inside the stated range.
By their numbers in this assay, from the lowest: compound 1; then compounds 3 and 2 (each within the scatter of the next).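

In this assay, going by these compounds alone, turning the stereocentre at a saturated chain carbon from S to R gives a 1.6-fold lower number from compound 2 to compound 3 (0.20 log units; within the scatter), the first reading of configuration at this position, and it stays within the scatter. This pair isolates configuration alone: the fact that compounds 2 and 3 differ only in the configuration as drawn. Methyl in place of hydrogen on an oxygen on a saturated carbon gives a 10-fold higher number from compound 1 to compound 3 (1.00 log units; beyond the scatter), so of the two single changes read here, this one carries the step beyond the scatter.

From the compounds shown here alone, what an amine or a longer alkyl chain would give in place of that methyl remains open. Also open, going by these compounds, is whether the configuration at the saturated chain carbon would count for as little when that oxygen carries hydrogen rather than methyl.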